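The source may hold more compounds than are shown below. What is called first, only, known or untested is meant among the compounds shown, and "the series" means these compounds.

Two isomeric scaffolds appear in this series. Compound 1 `O=C(COc1c(-c2ccccc2)oc2ccccc2c1=O)Nc1ccc(F)cc1` carries the oxyacetamide on the core, and in a functional assay on NPC-TW01 cells (Homo sapiens) for antiproliferative activity, read by MTT assay, with a stated time of 72 h (a higher number here means a weaker inhibitor of growth, a lower number a stronger inhibitor of growth), compound 1 gives 9500 nM. Compound 2 `O=C(COc1ccc2c(=O)c(-c3ccccc3)coc2c1)Nc1ccccc1` places the same side chain on the benzo ring of the core, and in this assay compound 2 gives > 10000 nM, which is a limit of the assay and not a number. So compound 2 stands at the weak edge of what is known here, a point marked by the limit of > 10000 nM in this assay, at which 1 of the 2 values shown sits.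

Compound 3 `COc1ccc(NC(=O)COc2ccc3c(=O)c(-c4ccccc4)coc3c2)cc1` differs from compound 2 only in the anilide: methoxy in place of hydrogen on an aromatic carbon. Among the compounds with values here, no measured step of this kind exists, so the expectation rests on compound 2 alone. A step in this assay of no more than the usual scatter is expected, with no clear direction, so that compound 3 most likely also ends at the limit. For compound 3 the estimate is 15000 nM, within 6000 nM to 40000 nM, an expected step that the limit leaves unreadable from compound 2 to compound 3.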

Compound 3, concentration for 50% growth inhibition: 6700 nM
Compound 3: middle estimate off by 2.2-fold (0.35 log units), on the high side; low and high end bracket the measured number.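

In this assay compound 3 gives 6700 nM, so with 4-methoxyphenyl on the amide nitrogen this scaffold yields a measured number, which compound 2 did not provide. Methoxy in place of hydrogen, para to a large group, gives an at least 1.4-fold lower number from compound 2 to compound 3 (0.17 log units; that floor lies within the scatter), so this floor alone does not establish a real gain in growth inhibition. The value of compound 2 is a limit of the assay and not a number, and the full size of the step stays unread because of it: the limit of > 10000 nM in this assay, at which 1 of the 3 values shown sits.

As far as these compounds go, whether an amine or a carboxylic acid at this same position would move the number further remains open. The two scaffolds also remain unseparated, since compound 1 differs from compound 3 in more than one place and the pair gives no clean comparison.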